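This account rests on a few compounds, and the source may have more. Where it says the series, first, only, none or still open, it means among the compounds named here.

Measured compounds:
compound 1, `COc1cccc(-c2c(S(=O)(=O)c3ccc(C)c(F)c3)cnc3c(F)cccc23)c1`, 4.02 mL/min
compound 2, `O=S(=O)(c1cc(Cl)cc(Cl)c1)c1cnc2c(F)cccc2c1-c1ccc(F)cc1`, 1.01 mL/min
compound 3, `COc1ccc(-c2c(S(=O)(=O)c3cc(Cl)cc(Cl)c3)cnc3c(F)cccc23)cc1`, 2.11 mL/min

These three compounds share one core and were tested in an ADME assay on microsomes from liver (Homo sapiens) for metabolic stability, tested at 2.5 uM; on this read-out higher numbers stand for fast clearance and lower numbers for slow clearance. Compound 2 has the lowest number of the three; its nearest neighbour is compound 3, at 2.11 mL/min, and the furthest is compound 1, at 4.02 mL/min. Among the compounds with values here, the only single change measured among them is the step of a 2.1-fold higher number from compound 2 to compound 3 (0.32 log units; beyond the scatter).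

Compound 4, `Cc1ccc(S(=O)(=O)c2cnc3c(F)cccc3c2-c2ccc(F)cc2)cc1F`, has not yet been measured. It differs from compound 2 in one place: 3-fluoro-4-methylphenyl in place of 3,5-dichlorophenyl on a sulfonyl sulfur. Within the data shown here, no measured step covers this exchange on the sulfonyl sulfur. Compound 1 carries the same 3-fluoro-4-methylphenyl group and gives 4.02 mL/min in this assay, but it also differs from compound 4 in the other aromatic group, so its value cannot be read as a step. With compound 2 at the low end of the range seen here, an upward step is expected, of size a 2.2-fold higher number from compound 2 to compound 4 (0.34 log units; beyond the scatter). Compound 4 is therefore estimated at 2.2 mL/min, with a range from 0.9 mL/min to 5.5 mL/min.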

Compound 4, intrinsic clearance in a liver preparation (reported as CLH), per the amount of preparation that the assay uses: 2.75 mL/min
Compound 4: middle estimate off by 1.3-fold (0.10 log units), on the low side; the measured number falls inside the stated range.
By their numbers in this assay, from the lowest: compound 2; then compounds 3, 4 and 1 (each within the scatter of the next).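

In this assay the group on the sulfonyl sulfur proves to matter: 3-fluoro-4-methylphenyl in place of 3,5-dichlorophenyl gives a 2.7-fold higher number from compound 2 to compound 4 (0.44 log units; beyond the scatter) and stays beyond the scatter. With 3-fluoro-4-methylphenyl held on the sulfonyl sulfur, the other aromatic group can also be exchanged, and 4-fluorophenyl in place of 3-methoxyphenyl gives a 1.5-fold lower number from compound 1 to compound 4 (0.16 log units; within the scatter), which is within the scatter and so shows no real difference between this pair. No supporting measurement is available to explain either step.

Because the exchange on the sulfonyl sulfur alters several atoms at once, the compounds shown cannot separate the contribution of the chlorines from that of the fluorine and the methyl. On these data alone, how a ring carrying an amine or a carboxylic acid, or a simple alkyl chain, would behave on the sulfonyl sulfur also remains open.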